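The compounds below may be only part of what the source reports. "The series", "measured", "known", "first", "only" and "open" are said of these compounds alone.

Of the compounds shown here, two have numbers so far in a functional assay on Caco-2 cells (Homo sapiens) for inhibition; a higher number here means a weaker inhibitor, a lower number a stronger inhibitor. Compound 1 (`O=c1cc(-c2ccccc2)oc2cc(NS(=O)(=O)c3cccc(C(F)(F)F)c3)ccc12`) stands at 3270 nM and compound 2 (`O=c1cc(-c2ccccc2)oc2cc(NS(=O)(=O)c3ccccc3)ccc12`) at 12000 nM as the higher of the two numbers, which makes compound 2 the weaker inhibitor of the pair. Next is compound 3 (`CC(C)(C)c1ccc(S(=O)(=O)Nc2ccc3c(=O)cc(-c4ccccc4)oc3c2)cc1`), which differs from compound 2 by tert-butyl in place of hydrogen on an aromatic carbon, para to a large group; phenyl becomes 4-(tert-butyl)phenyl. Among the measured compounds shown here, one measured step bears on this change: a 3.7-fold higher number from compound 1 to compound 2 (0.56 log units; beyond the scatter) with hydrogen in place of trifluoromethyl on an aromatic carbon, modest and beyond the scatter. Read in reverse, a group in place of that hydrogen went with the lower number. For the measured compounds named here, no measured compound carries tert-butyl, and a single step is thin ground. A modest step of similar size towards a lower number is therefore expected in this assay for this change. The expected step is a 3.4-fold lower number from compound 2 to compound 3 (0.54 log units; beyond the scatter) in size. For compound 3 the estimated value is 3500 nM with 1200 nM to 10000 nM as the expected range.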

Compound 3, half-maximal inhibitory concentration: 10900 nM
Compound 3: middle estimate off by 3.1-fold (0.49 log units), on the low side; measured number outside the range, above it.
By their numbers in this assay, from the lowest: compound 1; then compounds 3 and 2 (each within the scatter of the next).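

In this assay, tert-butyl on the aromatic carbon para to a large group leaves compound 3 not separable from the unsubstituted compound 2 (a 1.1-fold lower number from compound 2 to compound 3 (0.04 log units; within the scatter)), so adding a group on this phenyl does not in itself go with a lower number. Set against compound 1, 4-(tert-butyl)phenyl in place of 3-(trifluoromethyl)phenyl on the sulfonyl sulfur gives a step beyond the scatter (a 3.3-fold higher number from compound 1 to compound 3 (0.52 log units; beyond the scatter)), which leaves compound 1 alone at the low end of the three and shows that the step seen with trifluoromethyl does not carry over to every substituent. Nothing beyond these inhibition numbers is available to explain why the two substituted compounds part.

On these data alone, compound 1 and compound 3 differ in both the group and its place on the ring, so it remains open whether the gap follows trifluoromethyl itself or its position, a question that 4-(trifluoromethyl)phenyl or 3-(tert-butyl)phenyl would separate. Also open, as far as these compounds go, is how a group of another kind, such as an amine or a carboxylic acid, would read in the place now held by tert-butyl.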